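The source may hold more compounds than are shown below. What is called first, only, known or untested is meant among the compounds shown, and "the series" means these compounds.

Of the compounds shown here, two have been measured so far. Compound 1 `Cn1nc2c(=O)n(CC3(O)CCN(Cc4ccc(-c5ccoc5)cc4Cl)CC3)cnc2c1-c1ccc(CN)cc1` and compound 2 `Cn1nc2c(=O)n(CC3(O)CCN(Cc4ccc(-c5ccco5)cc4Cl)CC3)cnc2c1-c1ccc(OC(F)F)cc1` share one core and differ only in the group on the pendant phenyl ring. In an assay on isolated protein for inhibition of ubiquitin carboxyl-terminal hydrolase 7 (Homo sapiens), with stated times of 30 min and 2 h (a higher number here means a weaker inhibitor, a lower number a stronger inhibitor), compound 1 gives 177 nM, and in this assay compound 2 gives 179 nM. Compound 2 therefore holds the higher of the two numbers, but its nearest neighbour, compound 1, sits within the usual scatter of it, so the two values cannot be ordered against one another.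

Compound 3 `Cn1nc2c(=O)n(CC3(O)CCN(Cc4ccc(-c5ccco5)cc4Cl)CC3)cnc2c1-c1ccc(Cl)cc1` has not yet been measured. It differs from compound 2 in one place: chloro in place of difluoromethoxy on an aromatic carbon. Among the compounds with values here, no step between two measured compounds covers this kind of change, so there is no measured guide to its size. Given that the two measured substituents on this ring give values that cannot be told apart, the step of a 1.1-fold higher number from compound 2 to compound 3 (0.05 log units; within the scatter) is expected to stay inside the scatter, with no direction favoured. For compound 3 the estimated value in this assay is 200 nM, with a likely range from 80 nM to 500 nM.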

Compound 3, half-maximal inhibitory concentration: 143 nM
Estimate against measurement, compound 3: 1.4-fold (0.15 log units) above, within the range that was stated.
By their numbers in this assay, from the lowest: compounds 3, 1 and 2 (each within the scatter of the next).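

In this assay, chloro in place of difluoromethoxy, on an aromatic carbon para to a large group, gives a 1.3-fold lower number from compound 2 to compound 3 (0.10 log units; within the scatter), and this step lies within the scatter. Within the data shown here, this pair is the first direct comparison at this position with the rest of the structure held constant: four heavy atoms, including one hydrogen-bond acceptor, give way to a single chlorine atom with no readable change in the number. No measurement shown here offers an explanation for this result.

With only these two substituents compared directly, the pair does not show whether the position would tolerate other groups, such as a carboxylic acid, a nitrile or a longer alkoxy chain, as it tolerates this exchange. Compound 1 differs from compound 2 and compound 3 in more than one place, so the aminomethyl group on its phenyl ring cannot be assessed separately from the different attachment of its furan ring.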